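The source may hold more compounds than are shown below. What is called first, only, known or untested is meant among the compounds shown, and "the series" means these compounds.

Compound 1 `Nc1cc(N)c2nc(-c3ccccc3)c(NCc3ccc(Cl)c(Cl)c3)nc2c1` stands as the stronger of the two measured compounds. In a functional assay on SW-620 cells (Homo sapiens) for inhibition, read by sulforhodamine B assay, with a stated time of 48 h (a lower number here means a stronger inhibitor of growth, a higher number a weaker inhibitor of growth), compound 1 gives 3240 nM, while compound 2 `CCOC(=O)[C@H](CCC(=O)O)NC(=O)c1ccc(Sc2nc3cc(N)cc(N)c3nc2-c2ccccc2)cc1` gives 11700 nM, a gap beyond the usual scatter. Compound 3 `COc1ccc(CNc2nc3cc(N)cc(N)c3nc2-c2ccccc2)cc1` differs from compound 1 in one place: 4-methoxyphenyl in place of 3,4-dichlorophenyl on a saturated chain carbon bound to a nitrogen on an aromatic ring. Among the measured compounds shown here, no measured pair shows this change, so its effect must be estimated from what compound 1 shows. Expected is a small step toward a weaker inhibitor, a 1.5-fold higher number from compound 1 to compound 3 (0.19 log units; within the scatter), possibly within the scatter. Compound 3 is therefore expected to give about 5000 nM in this assay, within a range from 1500 nM to 20000 nM.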

Compound 3, concentration for 50% growth inhibition: 12900 nM
For compound 3 the middle estimate is 2.6-fold (0.41 log units) below the measured one, within the range that was stated.
By their numbers in this assay, from the lowest: compound 1; then compounds 2 and 3 (each within the scatter of the next).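

In this assay, putting 4-methoxyphenyl in place of 3,4-dichlorophenyl on a saturated chain carbon bound to a nitrogen on an aromatic ring gives a 4.0-fold higher number from compound 1 to compound 3 (0.60 log units; beyond the scatter). Among the compounds shown here, this is the first direct reading of this position, and it shows that growth inhibition responds to the group placed there. No measurement here accounts for the step.

A single swap cannot separate removing the chlorines from adding the methoxy group. A plain phenyl at this place could help to tell these apart, while a longer chain would ask a different question about the link itself.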